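From Methylamino to Phenyl on the Shared Core

A few compounds are considered here, and "the series" means these few. Any claim that something is new, unique, unknown or untested is made for them only; others in the source may bear on it.

In an ADME assay on microsomes from liver (Mus musculus) for metabolic stability (on this read-out lower numbers stand for slow clearance and higher numbers for fast clearance), compound 1 `CNc1ccnc2c(O)c(-c3nc(C)n[nH]3)ncc12` gives 3.1 mL.min-1.g-1, and compound 2 `Cc1n[nH]c(-c2ncc3c(NCc4ccc(Cl)cc4)ccnc3c2O)n1` gives 3.4 mL.min-1.g-1, which places the two within the scatter of each other. Compound 3 `Cc1n[nH]c(-c2ncc3c(-c4ccccc4)ccnc3c2O)n1` differs from compound 1 by phenyl in place of methylamino on an aromatic carbon, with phenyl in place of methylamino on an aromatic carbon. Within the data shown here, the only measured step, a 1.1-fold higher number from compound 1 to compound 2 (0.04 log units; within the scatter), keeps the nitrogen on that carbon, so it bears only loosely on this change. A small upward step is therefore expected, a 1.6-fold higher number from compound 1 to compound 3 (0.21 log units; within the scatter). Compound 3 is estimated at 5 mL.min-1.g-1, within a range of 2 mL.min-1.g-1 to 13 mL.min-1.g-1.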

Compound 3, intrinsic clearance in microsomes: 9.4 mL.min-1.g-1
Estimate against measurement, compound 3: 1.9-fold (0.27 log units) below, within the range that was stated.
By their numbers in this assay, from the lowest: compounds 1 and 2 (each within the scatter of the next); then compound 3.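

In this assay, phenyl in place of methylamino on this aromatic carbon gives a 3.0-fold higher number from compound 1 to compound 3 (0.48 log units; beyond the scatter) and so shows that this position does respond to a change of the atom bound directly to the ring. The earlier step, a 1.1-fold higher number from compound 1 to compound 2 (0.04 log units; within the scatter), kept the nitrogen on that carbon and stayed within the scatter. Nothing measured here accounts for the rise. From the compounds shown here alone, whether the rise follows the lost nitrogen or the directly attached ring stays open. An anilino group, which holds a phenyl ring on a nitrogen at this carbon, would separate the two.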